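Methoxy added to the anilino group of compound 2

This account rests on a few compounds, and the source may have more. Where it says the series, first, only, none or still open, it means among the compounds named here.

Measured so far:
- Compound 1 `Cc1ccc(-c2nn(-c3ccccc3)cc2C(=O)Nc2ccccc2)cc1`: in a functional assay on MCF7 cells (Homo sapiens) for cytotoxicity, read by MTT assay, with a stated time of 48 h (a higher number here means a weaker inhibitor, a lower number a stronger inhibitor), compound 1 gives 2450 nM
- Compound 2 `O=C(Nc1ccccc1)c1cn(-c2ccccc2)nc1-c1ccc(Cl)cc1`: in this assay compound 2 gives 2340 nM

Compound 2 stands level with compound 1: the step of a 1.0-fold lower number from compound 1 to compound 2 (0.02 log units; within the scatter) lies within the scatter. Compound 3 `COc1ccc(NC(=O)c2cn(-c3ccccc3)nc2-c2ccc(Cl)cc2)cc1` differs from compound 2 by methoxy in place of hydrogen on an aromatic carbon. Within the data shown here, no measured step touches this change; the single step known, chloro in place of methyl, sits on the other aromatic ring and says nothing about the anilino end. With no guidance, no step beyond the scatter is expected, so a 1.1-fold lower number from compound 2 to compound 3 (0.05 log units; within the scatter) is taken as roughly flat. For compound 3 in this assay the estimate is 2100 nM, with a range from 700 nM to 6500 nM.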

Compound 3, half-maximal inhibitory concentration: 1550 nM
Estimate against measurement, compound 3: 1.4-fold (0.13 log units) above, and the stated range covers the measured number.
By their numbers in this assay, from the lowest: compounds 3, 2 and 1 (each within the scatter of the next).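

In this assay, among these compounds, methoxy in place of hydrogen at the anilino end, on the carbon para to a large group, gives a first reading for this end of the series (a 1.5-fold lower number from compound 2 to compound 3 (0.18 log units; within the scatter)). This position therefore tolerates methoxy with no step beyond the scatter, whereas the earlier pair spoke only to chloro and methyl on the other aromatic ring. No available data explain this reading.

On these data alone, whether an amine, a carboxylic acid or a longer chain such as butoxy at this place would give a step beyond the scatter stays open. Also open, as far as these compounds go, is whether methoxy on the other aromatic rings would read the same.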